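From cyclopentyl to cycloheptyl on a shared core

The compounds below may be only part of what the source reports. "The series", "measured", "known", "first", "only" and "open" are said of these compounds alone.

Measured in a functional assay on MCF7 cells (Homo sapiens) for cytotoxicity, read by WST assay, with a stated time of 72 h; a lower number here means a stronger inhibitor, a higher number a weaker inhibitor:
- Compound 1 `Cc1ccc2c(c1C)NC(=O)C2(c1ccc(O)cc1)C1CCCCCC1`: 19 nM
- Compound 2 `Cc1c(Cl)ccc2c1NC(=O)C2(c1ccc(O)cc1)C1CCCCCC1`: 51 nM
- Compound 3 `COc1ccc2c(c1C)NC(=O)C2(c1ccc(O)cc1)C1CCCC1`: 1 nM

Compound 3 has the lowest number of the three, clearly beyond the scatter of both others. The next compound, compound 4 `COc1ccc2c(c1C)NC(=O)C2(c1ccc(O)cc1)C1CCCCCC1`, has not yet been measured in this assay. It keeps the rest of compound 3 and carries cycloheptyl in place of cyclopentyl on a saturated ring carbon.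

Among the compounds with values here, no measured step isolates this change. Within the data shown here, the only step between close neighbours is a 2.7-fold higher number from compound 1 to compound 2 (0.43 log units; beyond the scatter), a modest one, and it concerns chloro in place of methyl on an aromatic carbon, not the saturated ring. The indirect evidence is that both cycloheptyl compounds, compound 1 at 19 nM and compound 2 at 51 nM, have higher numbers than compound 3 at 1 nM, although compound 3 also differs from them elsewhere. A moderate rise, smaller than those gaps, is therefore expected. The estimate for compound 4 is 6 nM, within an expected range of 1.5 nM to 25 nM. This estimate means an expected 6.0-fold higher number from compound 3 to compound 4 (0.78 log units; beyond the scatter).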

Compound 4, half-maximal inhibitory concentration: 4.7 nM
For compound 4 the middle estimate is 1.3-fold (0.11 log units) above the measured one, and the stated range covers the measured number.
By their numbers in this assay, from the lowest: compound 3; then compound 4; then compound 1; then compound 2.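

Within the data shown here, with methoxy held on the aromatic carbon, the first direct reading of this change in this assay is a 4.7-fold higher number from compound 3 to compound 4 (0.67 log units; beyond the scatter), so enlarging the saturated ring substituent from cyclopentyl to cycloheptyl raises the number, but only modestly. With cycloheptyl held in place, the aromatic change can now also be read alone: there is a 4.0-fold lower number from compound 1 to compound 4 (0.61 log units; beyond the scatter) on replacing methyl with methoxy and an 11-fold lower number from compound 2 to compound 4 (1.04 log units; beyond the scatter) on replacing chloro with methoxy, which shows that the wide gap between compound 3 and the earlier cycloheptyl compounds did not come from the ring change alone. Nothing available explains either the ring-size step or the methoxy steps.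

The compounds shown leave open whether cyclohexyl, or an open chain such as n-pentyl, on this saturated ring carbon would fit between or beyond the cyclopentyl and cycloheptyl results. They also leave open whether methyl or chloro on the aromatic carbon would respond to the ring change as methoxy does, and whether ethoxy or an amine there would keep the low number seen with methoxy.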